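The source may hold more compounds than are shown below. What is called first, only, known or untested is meant among the compounds shown, and "the series" means these compounds.

In an ADME assay on cells (Hepatocyte, Mus musculus) for metabolic stability, with a stated time of 30 min (on this read-out lower numbers stand for a less stable compound and higher numbers for a more stable compound), compound 1 (`O=c1cc(N2CCN(CC3CCCCC3)CC2)sc2c(NO)cc(C(F)(F)F)cc12`) retains 47.8%, while compound 2 (`O=C(OC1CCC(CN2CCN(c3cc(=O)c4cc(C(F)(F)F)cc([N+](=O)[O-])c4s3)CC2)CC1)c1ccncc1`) gives 1.4%, the lower of the two numbers and a gap beyond the scatter. Compound 3 (`CC(=O)NC1CCC(CN2CCN(c3cc(=O)c4cc(C(F)(F)F)cc([N+](=O)[O-])c4s3)CC2)CC1`) carries acetamido in place of ((pyridin-4-yl)carbonyl)oxy on a saturated ring carbon. Within the data shown here, no measured step covers this change. With compound 2 at 1.4%, little room remains downward. An upward step beyond the scatter is therefore expected in this assay, estimated as a number 23.6 percentage points higher from compound 2 to compound 3 (beyond the scatter). The expected value for compound 3 is 25%, within an estimated range of 8% to 50%.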

Compound 3, percent of the compound remaining: 94.9%
For compound 3 the middle estimate is 69.9 percentage points below the measured one, outside the stated range (above it).
By their numbers in this assay, from the lowest: compound 2; then compound 1; then compound 3.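

In this assay, the group on this saturated ring carbon alone proves decisive with the rest of the structure unchanged: acetamido in place of ((pyridin-4-yl)carbonyl)oxy gives a number 93.5 percentage points higher from compound 2 to compound 3 (beyond the scatter). The change removes a six-membered aromatic ring and adds the amide hydrogen in a single step, so these two differences cannot be told apart. No available evidence bears on what underlies this step. From the compounds shown here alone, whether a hydroxy group or an amine on the same carbon would stay close to compound 3 at 94.9% remains open.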